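The source may report more compounds than this note shows. Statements on the series, on what has been measured and on what is new or still open speak of the compounds shown alone.

Compound 1, with the structure `OC[C@H]1O[C@@H](n2cnc3c(NCc4ccccc4Br)ncnc32)[C@H](O)[C@@H]1O`, is the starting point of this account. In a functional assay on B16 cells (Mus musculus) for antiproliferative activity, with a stated time of 72 h (a lower number here means a stronger inhibitor, a higher number a weaker inhibitor), compound 1 gives > 166000 nM, which is a limit of the assay rather than a measured number. Its two neighbours sit the same way. Compound 2, `OC[C@H]1O[C@@H](n2cnc3c(NCc4cccc(Br)c4)ncnc32)[C@H](O)[C@@H]1O`, gives > 166000 nM in this assay, again a limit. Compound 3, `COc1cccc(CNc2ncnc3c2ncn3[C@@H]2O[C@H](CO)[C@@H](O)[C@H]2O)c1`, gives > 166000 nM in this assay, also a limit. Because of the limit of > 166000 nM in this assay, at which 3 of the 3 values shown sit, none of the steps among these three can be read: the change from compound 1 to compound 2 is a step that the two limits leave unreadable from compound 1 to compound 2, from compound 1 to compound 3 it is a step that the two limits leave unreadable from compound 1 to compound 3, and from compound 2 to compound 3 it is a step that the two limits leave unreadable from compound 2 to compound 3.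

Compound 4, `Cc1cccc(CNc2ncnc3c2ncn3[C@@H]2O[C@H](CO)[C@@H](O)[C@H]2O)c1O`, shares the core of compound 1 and differs from it by 2-hydroxy-3-methylphenyl in place of 2-bromophenyl on a saturated chain carbon bound to a nitrogen on an aromatic ring. The three measured steps bear on it only as limits, so they give no size and no direction for the change; what they show is that every variation of the group on this saturated chain carbon so far has left the value at the limit. The step from compound 1 to compound 4 is therefore expected to be a number no higher from compound 1 to compound 4 (the limit leaves the size open), which is no step beyond the scatter. Compound 4 is estimated at 166000 nM, in the range from 60000 nM to 500000 nM, and it is expected that this assay will most likely again report only a limit.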

Compound 4, half-maximal inhibitory concentration: > 166000 nM
Compound 4: no number, only a limit; the forecaster's own chance of this, stated with the estimate: 80%; the middle value sits exactly at the limit.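

In this assay compound 4 gives > 166000 nM, which is a limit. No step linking compound 4 with compound 1, compound 2 or compound 3 can be read, because the values stop at one limit: the limit of > 166000 nM in this assay, at which 4 of the 4 values shown sit.

The compounds shown leave open whether any group on this saturated chain carbon gives a measurable value, and how large a step it would be.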